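The source may report more compounds than this note shows. Statements on the series, on what has been measured and on what is new or still open speak of the compounds shown alone.

Measured in a functional assay on the whole organism (strain Sprague-Dawley) for inhibition, with Rattus norvegicus as the target, with a stated time of 10 min; on this read-out higher numbers stand for an effect only at larger amounts of compound and lower numbers for an effect already at smaller amounts:
Compound 1 `CCOC(=O)c1cnc(-c2cc(OC)ccc2OCC)[nH]c1=O`: 0.3 mg/kg
Compound 2 `CCOC(=O)c1cnc(-c2cc(N)ccc2OCC)[nH]c1=O`: 0.5 mg/kg

For the measured compounds named here, compound 2 stands within the usual scatter of compound 1, the only other measured compound, so the two numbers mark a single level. Compound 3 `CCOC(=O)c1cnc(-c2cc(S(=O)(=O)N(CC)CC)ccc2OCC)[nH]c1=O` differs from compound 2 in one place: diethylsulfamoyl in place of amino on an aromatic carbon. Diethylsulfamoyl takes the place of amino on an aromatic carbon, para to an ethoxy group. Going by the values given here, only one measured step bears on this, a 1.7-fold higher number from compound 1 to compound 2 (0.22 log units; within the scatter), with amino in place of methoxy, and it lies within the scatter. Among the compounds with values here, that step offers limited guidance, since no measured compound carries a group as large as diethylsulfamoyl. A moderate move toward a higher number is therefore expected in this assay, with wide uncertainty. The expected step is a 2.0-fold higher number from compound 2 to compound 3 (0.30 log units; within the scatter). Compound 3 is estimated at 1 mg/kg, with an expected range from 0.2 mg/kg to 5 mg/kg.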

Compound 3, dose for 50% inhibition: 10 mg/kg
Estimate against measurement, compound 3: 10-fold (1.00 log units) below, outside the stated range (above it).
By their numbers in this assay, from the lowest: compounds 1 and 2 (each within the scatter of the next); then compound 3.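

In this assay, methoxy and amino on this aromatic carbon, para to an ethoxy group, had marked a single level, but this position does not treat all groups alike: diethylsulfamoyl gives a 20-fold higher number from compound 2 to compound 3 (1.30 log units; beyond the scatter) and a 33-fold higher number from compound 1 to compound 3 (1.52 log units; beyond the scatter), both large and beyond the scatter. The change replaces amino, with 1 heavy atom and 1 hydrogen-bond donor, with a group of 8 heavy atoms and 0 hydrogen-bond donors that also brings in sulfur, and this single step cannot tell these differences apart. No measurement at hand accounts for the higher number.

The compounds shown leave open whether the ethyl groups matter, which a plain sulfamoyl or a dimethylsulfamoyl at this position would test. They also leave open how a carboxylic acid or a carboxamide would read here.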